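The compounds below may be only part of what the source reports. "The series", "measured", "known", "first", "only" and "open" are said of these compounds alone.

Working notes on the series in a functional assay on the whole organism (strain albino) for inhibition, with Rattus norvegicus as the target, read by paw edema, with stated times of 30 min and 3 h, at a dose of 100 mg/kg by the oral route; on this read-out lower numbers stand for less inhibition and higher numbers for more inhibition at the one dose given (going by the name of the read-out).

Compound 1 `COc1ccc(C2=NN(C(=O)CBr)C(c3ccco3)C2)cc1OC` gives 51% in this assay. Compound 2 `COc1ccc(C2=NN(C(=O)CBr)C(c3c(Cl)cccc3Cl)C2)cc1OC` gives 69%, and compound 3 `COc1ccc(C2=NN(C(=O)CBr)C(c3c(Cl)cccc3Cl)C2)cc1` gives 7%. The step of a number 18 percentage points higher from compound 1 to compound 2 (beyond the scatter) comes with 2,6-dichlorophenyl in place of furan-2-yl on a saturated ring carbon. The step of a number 62 percentage points lower from compound 2 to compound 3 (beyond the scatter) comes with hydrogen in place of methoxy on an aromatic carbon. Compound 2 stands highest of the three numbers in this assay, with compound 1 nearest and compound 3 furthest.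

Compound 4 `COc1ccc(C2=NN(C(=O)C(C)Br)C(c3c(Cl)cccc3Cl)C2)cc1OC` differs from compound 2 as follows: methyl in place of hydrogen on a saturated chain carbon bound to a bromine atom and a carbonyl carbon. Neither measured step touches this part of the molecule: one changes the group on a saturated ring carbon, the other a methoxy on an aromatic carbon, and both leave the bromomethyl carbonyl untouched. For the measured compounds named here, no measured step bears directly on the change, so the expectation for compound 4 in this assay rests on compound 2 alone, and a step no larger than the scatter, in either direction, is expected, written as a number 6 percentage points lower from compound 2 to compound 4 (within the scatter). Compound 4 is therefore estimated at 63%, with a range from 42% to 80%.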

Compound 4, a percentage reported as inhibition, in the whole organism at one dose (the size of the read-out at that dose, not a potency): 60%
Beside the measured number, compound 4's estimate is 3 percentage points above it; the range from low to high includes it.
By their numbers in this assay, from the lowest: compound 3; then compounds 1, 4 and 2 (each within the scatter of the next, the first and the last beyond it).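

In this assay, for the compounds shown here, the carbon bound to a bromine atom and a carbonyl carbon is changed here for the first time, and methyl in place of hydrogen gives a number 9 percentage points lower from compound 2 to compound 4 (within the scatter) at the one dose given. The position therefore accepts bromomethyl to 1-bromoethyl with no step beyond the scatter, unlike the two earlier changes elsewhere in the molecule, of which the larger is a number 62 percentage points lower from compound 2 to compound 3 (beyond the scatter) and the smaller a number 18 percentage points higher from compound 1 to compound 2 (beyond the scatter). No measured evidence explains why this step stays so small.

The compounds shown leave open whether a longer chain such as ethyl on this carbon, or an amine in place of the bromine atom, would keep the number within the scatter of compound 2. As far as these compounds go, the 1-bromoethyl group also appears only with the 2,6-dichlorophenyl group and both methoxy groups, so its effect alongside furan-2-yl remains open.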